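A few compounds are considered here, and "the series" means these few. Any claim that something is new, unique, unknown or untested is made for them only; others in the source may bear on it.

Among the measured compounds shown here, in a functional assay on MCF7 cells (Homo sapiens) for inhibition, with a stated time of 96 h (on this read-out higher numbers stand for weaker inhibition and lower numbers for stronger inhibition), three compounds sharing one core have numbers so far. Compound 1 `COc1cc(C(=O)c2cn(-c3cccc(C)c3)cc2-c2ccoc2)cc(OC)c1OC` gives 21 nM, compound 2 `COc1cc(C(=O)c2cn(-c3ccc(C)cc3)cc2-c2ccsc2)cc(OC)c1OC` gives 4 nM, and compound 3 `COc1cc(C(=O)c2cn(-c3ccc(C)cc3)cc2-c2ccoc2)cc(OC)c1OC` gives 18 nM. Compound 3 therefore stands within the scatter of compound 1 and clearly above compound 2. Compound 4 `COc1cc(C(=O)c2cn(-c3ccc(C)cc3)cc2-c2ncco2)cc(OC)c1OC` differs from compound 3 in one place, with 1,3-oxazol-2-yl in place of furan-3-yl on an aromatic carbon. For the measured compounds named here, the closest precedent is the exchange of thiophen-3-yl for furan-3-yl at that same place, which gave a 4.5-fold higher number from compound 2 to compound 3 (0.65 log units; beyond the scatter). The exchange of 3-methylphenyl for 4-methylphenyl on the aromatic nitrogen, a 1.2-fold lower number from compound 1 to compound 3 (0.07 log units; within the scatter), lies elsewhere on the molecule and says little here. Going by the values given here, no measured compound carries the incoming group, so the direction remains uncertain. A modest move toward a higher number is expected in this assay, estimated as a 3.3-fold higher number from compound 3 to compound 4 (0.52 log units; beyond the scatter). Compound 4 is expected at about 60 nM, with an estimated range from 15 nM to 250 nM.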

Compound 4, half-maximal inhibitory concentration: 42 nM
The estimate for compound 4 lay 1.4-fold (0.15 log units) above the measured number; measured number inside the range.
By their numbers in this assay, from the lowest: compound 2; then compounds 3, 1 and 4 (each within the scatter of the next, the first and the last beyond it).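

The place on the five-membered aromatic ring with 1 nitrogen, two ring bonds from the ring atom that bears the 4-methylphenyl group, now has three groups compared on the same background, and it responds to a second ring exchange, not only to the first. In this assay, 1,3-oxazol-2-yl in place of furan-3-yl gives a 2.3-fold higher number from compound 3 to compound 4 (0.37 log units; beyond the scatter), while the same group in place of thiophen-3-yl gives an 11-fold higher number from compound 2 to compound 4 (1.02 log units; beyond the scatter), a large step that puts thiophen-3-yl well ahead of 1,3-oxazol-2-yl. Nothing available explains why these five-membered rings differ in this way.

From the compounds shown here alone, whether a phenyl ring, a pyridine ring or an open chain such as an amine would be tolerated at this place remains open. So does whether the same order of rings would hold with 3-methylphenyl on the ring nitrogen.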